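Shifting the chlorine from 3-chlorophenyl to 2-chlorophenyl

A few compounds are considered here, and "the series" means these few. Any claim that something is new, unique, unknown or untested is made for them only; others in the source may bear on it.

Measured compounds:
compound 1 `Clc1cccc(-c2cc(-c3ccc(Cl)o3)cc(-c3cccs3)n2)c1` — 12800 nM
compound 2 `Clc1ccc(-c2cc(-c3cccnc3)nc(-c3ccsc3)c2)o1` — > 50000 nM

In a functional assay on HeLa cells (Homo sapiens) for cytotoxicity, in the presence of a further agent that is not named here (on this read-out lower numbers stand for stronger inhibition and higher numbers for weaker inhibition), compound 1 gives 12800 nM. For compound 2 the read-out is a limit of the assay, > 50000 nM, and not a number; this is the limit of > 50000 nM in this assay, at which 1 of the 2 values shown sits. Going by the values given here, compound 1 therefore stands as the only concrete value in this assay, with the one further entry being a limit.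

Compound 3 `Clc1ccc(-c2cc(-c3cccs3)nc(-c3ccccc3Cl)c2)o1` is the next compound for this assay. It has the same atoms as compound 1, joined differently: 2-chlorophenyl in place of 3-chlorophenyl on an aromatic carbon. Among the compounds with values here, no pair of measured compounds differs in a single place, so there is no measured step in this assay to set the size of this change against. With only the value of compound 1 as an anchor, the expectation for the step from compound 1 to compound 3 is modest, a change of a 1.3-fold higher number from compound 1 to compound 3 (0.10 log units; within the scatter) that lies within the usual scatter. Compound 3 is accordingly estimated at 16000 nM in this assay, with a range from 5000 nM to 50000 nM.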

Compound 3, half-maximal inhibitory concentration: 18500 nM
Compound 3: the middle estimate sits 1.2-fold (0.06 log units) below what was measured, and the stated range covers the measured number.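

Moving the chlorine from 3-chlorophenyl to 2-chlorophenyl, on the aromatic carbon next to the ring nitrogen, gives the first comparison in this assay of two compounds that differ in one place (a 1.4-fold higher number from compound 1 to compound 3 (0.16 log units; within the scatter)). The step stays within the scatter, so this read-out does not separate the two chlorine placements, and compound 1 and compound 3 cannot be ranked against each other. The values shown carry no information on the reason for this outcome, and the one limit among them does not bear on the step.

Still open, on these data alone, is what the chlorophenyl group contributes at this position, since the one-place comparison covers only these two chlorine placements and says nothing about an unsubstituted phenyl, a 4-chlorophenyl, or a phenyl carrying an amine or a carboxylic acid. Going by these compounds alone, compound 2 remains a limit of the assay and not a number (> 50000 nM), and it forms no one-place step with compound 1 or compound 3, so the 3-pyridyl and thiophen-3-yl groups it carries cannot be assessed separately.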